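A 4-methylbenzyl amide after the limit of compound 3

A few compounds are considered here, and "the series" means these few. Any claim that something is new, unique, unknown or untested is made for them only; others in the source may bear on it.

Compound 1, `O=C(CN1C(=O)/C(=C/c2ccc(-c3ccc(Cl)cc3)o2)SC1=S)NCc1ccc(C(F)(F)F)cc1`, gives 155000 nM in a functional assay on K562 cells (Homo sapiens) for cytotoxicity, read by MTT assay, with a stated time of 72 h; on this read-out lower numbers stand for stronger inhibition and higher numbers for weaker inhibition.
Compound 2, `N#Cc1ccc(NC(=O)CN2C(=O)/C(=C/c3ccc(-c4ccc(Cl)cc4)o3)SC2=S)cc1`, gives 85000 nM in this assay.
Compound 3, `N#Cc1cc(NC(=O)CN2C(=O)/C(=C/c3ccc(-c4ccc(Cl)cc4)o3)SC2=S)ccc1C(F)(F)F`, reaches only a limit of the assay, > 250000 nM, in this assay.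

Compound 3 thus stands at the limit of > 250000 nM in this assay, at which 1 of the 3 values shown sits, with no number of its own. The step to compound 4, `Cc1ccc(CNC(=O)CN2C(=O)/C(=C/c3ccc(-c4ccc(Cl)cc4)o3)SC2=S)cc1`, is 4-methylbenzyl in place of 3-cyano-4-(trifluoromethyl)phenyl on an amide-type nitrogen. Among the compounds with values here, no measured step makes this exact change, but the steps into compound 3 bear on it: an at least 1.6-fold higher number from compound 1 to compound 3 (0.20 log units; that floor lies within the scatter) and an at least 2.9-fold higher number from compound 2 to compound 3 (0.46 log units; beyond the scatter), while a 1.8-fold lower number from compound 1 to compound 2 (0.26 log units; within the scatter). Compound 4 returns to a benzyl group on the amide-type nitrogen, as in compound 1, so the reverse of the step from compound 1 to compound 3 is the nearest guide, and a step in this assay from compound 3 to compound 4 toward a lower number is expected, at least modest in size, since compound 3 sits at the limit. For compound 4 the estimated step is an at least 1.6-fold lower number from compound 3 to compound 4 (0.22 log units; that floor lies within the scatter). Compound 4 is expected to give about 150000 nM in this assay, within a range from 60000 nM to 260000 nM, guided by compound 1 with 155000 nM.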

Compound 4, half-maximal inhibitory concentration: 45000 nM
Estimate against measurement, compound 4: 3.3-fold (0.52 log units) above; the measured number lies below the stated range.
By their numbers in this assay, from the lowest: compounds 4, 2 and 1 (each within the scatter of the next, the first and the last beyond it). At a limit, above all of these: compound 3.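

In this assay, within the data shown here, a change confined to the substituent on the benzyl ring already moves the value, with methyl in place of trifluoromethyl on an aromatic carbon giving a 3.4-fold lower number from compound 1 to compound 4 (0.54 log units; beyond the scatter), whereas the earlier compounds held no pair that differed only there. The change from 3-cyano-4-(trifluoromethyl)phenyl to 4-methylbenzyl on the amide-type nitrogen gives an at least 5.5-fold lower number from compound 3 to compound 4 (0.74 log units; beyond the scatter), and that size is only a floor, since one partner of the pair holds a limit of the assay and no number of its own: the limit of > 250000 nM in this assay, at which 1 of the 4 values shown sits. Among these compounds, the change from 4-cyanophenyl to 4-methylbenzyl gives a 1.9-fold lower number from compound 2 to compound 4 (0.28 log units; within the scatter), so that pair cannot be put in order and no compound here stands apart as the strongest.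

The compounds shown leave open whether the methyl group itself matters, which an unsubstituted benzyl, a 4-chlorobenzyl or a 4-methoxybenzyl amide would test. They also leave open what the single carbon of the benzyl group contributes, which a 4-methylphenyl group directly on the amide-type nitrogen or a longer 2-phenylethyl chain would help to separate.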